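Replacing the Cyclic Amidine of Compound 1 with Pyrrolidinylmethyl

The source may report more compounds than this note shows. Statements on the series, on what has been measured and on what is new or still open speak of the compounds shown alone.

Compound 1 `COc1ccc(Sc2ccc(NC3=NC(C)CN3)cc2)cc1` is the stronger of the two measured compounds in an assay (Rattus norvegicus) for binding affinity to prostacyclin receptor (Homo sapiens), read by radioligand binding (on this read-out higher numbers stand for weaker inhibition and lower numbers for stronger inhibition), where compound 1 gives 63.1 nM. Compound 2 `COc1ccc(Sc2ccc(NC3=NCCCCN3)cc2)cc1` gives 1260 nM in this assay; the step of a 20-fold higher number from compound 1 to compound 2 (1.30 log units; beyond the scatter) accompanies nothing more than an enlargement of the ring on the nitrogen attached to the aromatic ring, with both ring nitrogens and the double bond retained.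

Compound 3 `COc1ccc(Sc2ccc(CN3CCCC3)cc2)cc1` has not been measured. Relative to compound 1 the change is a group of 6 heavy atoms (5 carbon, 1 nitrogen; one five-membered non-aromatic ring with 1 hetero atom) in place of a group of 7 heavy atoms (4 carbon, 3 nitrogen; one five-membered non-aromatic ring with 2 hetero atoms), on an aromatic carbon. Within the data shown here, the step from compound 1 to compound 2 is the only measured step that bears on this change, and it bears on it only loosely: there the ring nitrogens, the double bond and both hydrogen-bond donors survived, and the number still rose by a large margin. In compound 3 all of these are gone and the group is attached through carbon rather than nitrogen. The step of a 40-fold higher number from compound 1 to compound 3 (1.60 log units; beyond the scatter) is therefore expected to be a weakening beyond the scatter, with wide uncertainty. Compound 3 is estimated at 2500 nM in this assay, within a range from 300 nM to 20000 nM.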

Compound 3, inhibition constant: 10000 nM
Compound 3: middle estimate off by 4.0-fold (0.60 log units), on the low side; the range from low to high includes it.
By their numbers in this assay, from the lowest: compound 1; then compound 2; then compound 3.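

At this aromatic carbon, placing (pyrrolidin-1-yl)methyl in the position of the group in compound 1 gives a 160-fold higher number from compound 1 to compound 3 (2.20 log units; beyond the scatter) in this assay. The earlier step changed only the size of the ring and kept its two nitrogens, whereas this one shows that keeping a five-membered non-aromatic ring does not preserve the number when the group entering has one ring nitrogen, no hydrogen-bond donors and a carbon link to the aromatic ring. Nothing available here explains this step.

The compounds shown leave open which part of the change carries the step, as the ring atoms, the hydrogen-bond donors and the link to the aromatic ring all change together in compound 3. Also open, on these data alone, is how a simple aminomethyl group, a dimethylaminomethyl group or a guanidine on the same aromatic carbon would read in this assay, and such groups could begin to separate these parts of the change.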